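Reversing the enone in a trimethoxyphenyl series

The source may report more compounds than this note shows. Statements on the series, on what has been measured and on what is new or still open speak of the compounds shown alone.

Of the two compounds measured in a functional assay on DU-145 cells (Homo sapiens) for antiproliferative activity, read by MTT assay, with a stated time of 24 h (a lower number here means a stronger inhibitor, a higher number a weaker inhibitor), compound 2 `COc1cc(-c2cc(/C=C/C(=O)c3ccc(C)c(C)c3)nc3cc(-c4ccccc4)nn23)cc(OC)c1OC` gives 15400 nM, the lowest of the two numbers. Its nearest neighbour is compound 1 `COc1cc(-c2cc(/C=C/C(=O)c3ccc(C)cc3)nc3cc(-c4ccccc4)nn23)cc(OC)c1OC`, which in this assay gives 27100 nM; the step of a 1.8-fold lower number from compound 1 to compound 2 (0.25 log units; within the scatter) lies within the scatter. Compound 3 `COc1cc(-c2cc(C(=O)/C=C/c3ccc(C)cc3)nc3cc(-c4ccccc4)nn23)cc(OC)c1OC` differs from compound 2 by (2-(4-methylphenyl)ethenyl)carbonyl in place of 2-((3,4-dimethylphenyl)carbonyl)ethenyl on an aromatic carbon. Within the data shown here, only one measured step bears on this change: the added methyl from compound 1 to compound 2, which did not move the number beyond the scatter. Among the measured compounds shown here, no measured pair shows what exchanging the two ends of the enone does, and the loss of one methyl, judged from compound 1 against compound 2, is expected to matter little. Compound 3 is therefore expected to stay near the two measured values, the estimated step being a 1.6-fold higher number from compound 2 to compound 3 (0.19 log units; within the scatter). The estimate for compound 3 in this assay is 24000 nM, within 8000 nM to 75000 nM.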

Compound 3, half-maximal inhibitory concentration: 21900 nM
The estimate for compound 3 lay 1.1-fold (0.04 log units) above the measured number; the range from low to high includes it.
By their numbers in this assay, from the lowest: compounds 2, 3 and 1 (each within the scatter of the next).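

In this assay, among these compounds, compound 3 gives the first direct reading of the enone reversal. Compound 1 and compound 3 carry the same 4-methylphenyl end and differ only in the direction of the linker: the exchange is a 1.2-fold lower number from compound 1 to compound 3 (0.09 log units; within the scatter), so the two orientations are not told apart at this position. The step of a 1.4-fold higher number from compound 2 to compound 3 (0.15 log units; within the scatter), which also involves one methyl fewer on the aromatic ring, likewise does not separate the two compounds. No measurement on hand explains these numbers.

As far as these compounds go, it remains open whether an amine or a carboxylic acid on that aromatic ring, in place of methyl, would give a step beyond the scatter. Also open, from the compounds shown here alone, is what a saturated ethyl link in place of the ethenyl, or a plain phenyl in place of the 3,4,5-trimethoxyphenyl group, would do.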